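The source may report more compounds than this note shows. Statements on the series, on what has been measured and on what is new or still open speak of the compounds shown alone.

Working notes on the series

Compounds 1 and 2 share one core; compound 3 and compound 4 share another. Compound 1 `COc1ccc(Cn2c(NCCNC(=N)N)nc(=O)n(Cc3ccc(Br)cc3)c2=O)cc1` carries a 4-bromobenzyl group, compound 2 `COc1ccc(Cn2c(NCCNC(=N)N)nc(=O)n(Cc3ccc(F)cc3)c2=O)cc1` a 4-fluorobenzyl group, and compound 3 `COc1ccc(Cn2c(=O)nc(NCCNC(=N)N)n(Cc3ccc(F)cc3)c2=O)cc1` is built from the same atoms as compound 2, joined differently; the difference between the two cores is not broken down here. Compound 4 `COc1ccc(Cn2c(=O)nc(NCCNC(=N)N)n(Cc3ccc(Br)cc3)c2=O)cc1` is the bromo counterpart of compound 3 and has not been measured.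

In a functional assay on the whole organism (strain C57Bl/6) for inhibition, with Mus musculus as the target, with a stated time of 180 min, at 48 degrees C (a lower number here means that less compound is needed, a higher number that more compound is needed for the effect), compound 2 gives 0.00031 nM. Compound 1 gives 0.00036 nM in this assay, so the change bromo in place of fluoro on an aromatic carbon produced a 1.2-fold higher number from compound 2 to compound 1 (0.06 log units; within the scatter). Compound 3 gives 0.036 nM in this assay, the highest of the three numbers and beyond the scatter against both compound 1 and compound 2.

The change from compound 3 to compound 4 is bromo in place of fluoro on an aromatic carbon, the same change as from compound 2 to compound 1, at the same place. No second instance on the core of compound 3 exists, so the expectation rests on one measured pair. Because a 1.2-fold higher number from compound 2 to compound 1 (0.06 log units; within the scatter) lies within the scatter, the step for compound 4 is expected to be small, a 1.1-fold higher number from compound 3 to compound 4 (0.05 log units; within the scatter). Compound 4 is therefore expected to give about 0.04 nM in this assay. The range for compound 4 is estimated to run from 0.012 nM to 0.13 nM.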

Compound 4, half-maximal effective concentration: 0.0043 nM
For compound 4 the middle estimate is 9.3-fold (0.97 log units) above the measured one; the measured number lies below the stated range.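

Bromo in place of fluoro does not carry over unchanged from one core to the other in this assay: the same change on two cores in this assay, a 1.2-fold higher number (0.06 log units; within the scatter) from compound 2 to compound 1 and an 8.4-fold lower number (0.92 log units; beyond the scatter) from compound 3 to compound 4, 9.7-fold (0.99 log units) apart, beyond the scatter of two such steps. The exchange gives an 8.4-fold lower number from compound 3 to compound 4 (0.92 log units; beyond the scatter), whereas on the other core the same exchange stays within the scatter, so in this series a step read on one of these cores is a poor guide to the step on the other. This rests on a single pair per core, and it does not show why the two cores respond differently, whether the gap would hold for other exchanges at this place, or whether compound 4 would keep its number in any other assay.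

The compounds shown leave open whether a chloro group, a nitrile or a carboxylic acid in place of the bromo on the 4-bromobenzyl group would separate the two cores in the same way, or whether the split belongs to bromo alone. They also leave open whether the gap between the cores would persist with a longer chain or a simple amine in place of the chain that both cores carry now.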